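This account rests on a few compounds, and the source may have more. Where it says the series, first, only, none or still open, it means among the compounds named here.

Working notes on the series. Of the compounds shown here, three have been measured in an assay for inhibition of acid-sensing ion channel 3 (Homo sapiens), read by patch clamp, tested at 20 uM; a lower number here means less inhibition, a higher number more inhibition at the concentration tested (going by the name of the read-out). Compound 1 `NC(N)=NC(=O)c1nc(Cl)c(NCc2ccc(Cl)cc2)nc1N` gives 97%, compound 2 `CCCNc1nc(N)c(C(=O)N=C(N)N)nc1Cl` gives 91%, and compound 3 `CC(C)(C)Nc1nc(N)c(C(=O)N=C(N)N)nc1Cl` gives 48%. Compound 3 stands lowest of the three: its nearest neighbour is compound 2, and compound 1 lies further off still, both gaps beyond the scatter. The two measured steps: ethyl in place of 4-chlorophenyl on a saturated chain carbon bound to a nitrogen on an aromatic ring gave a number 6 percentage points lower from compound 1 to compound 2 (within the scatter), whereas tert-butyl in place of propyl on a nitrogen on an aromatic ring gave a number 43 percentage points lower from compound 2 to compound 3 (beyond the scatter).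

Compound 4 `NC(N)=NC(=O)c1nc(Cl)c(NCC2CCCCC2)nc1N` is not yet measured. It differs from compound 3 as follows: cyclohexylmethyl in place of tert-butyl on a nitrogen on an aromatic ring. The step from compound 2 to compound 3 is the one that bears most directly on this change, since it shows that replacing propyl by tert-butyl at this nitrogen cost a number 43 percentage points lower from compound 2 to compound 3 (beyond the scatter); the step from compound 1 to compound 2 shows that a chain carbon bound to the nitrogen carrying either a ring or a short chain gave values within the scatter of each other. Compound 4 restores a saturated chain carbon at that nitrogen, so an upward step is expected, a number 37 percentage points higher from compound 3 to compound 4 (beyond the scatter). Compound 4 is therefore estimated at 85%, with a range from 65% to 98%.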

Compound 4, a percentage reported as inhibition, at one concentration (the size of the read-out at that concentration, not a potency): 96%
The estimate for compound 4 lay 11 percentage points below the measured number; the range from low to high includes it.
By their numbers in this assay, from the lowest: compound 3; then compounds 2, 4 and 1 (each within the scatter of the next).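

In this assay, cyclohexylmethyl in place of tert-butyl on a nitrogen on an aromatic ring gives a number 48 percentage points higher from compound 3 to compound 4 (beyond the scatter) and so reverses the earlier loss with a group of more heavy atoms, 7 carbon against 4 carbon, which means that the low number of compound 3 does not follow from group size counted in heavy atoms. On the saturated chain carbon bound to that nitrogen, cyclohexyl in place of ethyl gives a number 5 percentage points higher from compound 2 to compound 4 (within the scatter) and cyclohexyl in place of 4-chlorophenyl gives a number 1 percentage points lower from compound 1 to compound 4 (within the scatter) in the same assay. Going by these compounds alone, a short chain, an aromatic ring and a six-membered non-aromatic ring of carbon only on that chain carbon therefore read alike, and tert-butyl, in compound 3, is the one group that goes against this pattern.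

The compounds shown leave open how isopropyl on that nitrogen would read, and whether a carboxylic acid or an amine at the end of a propyl chain would hold the number of compound 2 at 91% or lose it. No evidence is at hand on why tert-butyl stands apart from the other three groups.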